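A few compounds are considered here, and "the series" means these few. Any claim that something is new, unique, unknown or untested is made for them only; others in the source may bear on it.

Measured in a functional assay on SMMC-7721 cells (Homo sapiens) for antiproliferative activity, read by MTT assay, with a stated time of 48 h (a higher number here means a weaker inhibitor, a lower number a stronger inhibitor), so far:
- compound 1 `Cn1cc(C2=C(c3nn(CCCn4cncn4)c4ncccc34)C(=O)NC2=O)c2ccccc21` gives > 100000 nM as a limit, not a number
- compound 2 `Cn1cc(C2=C(c3nn(CCCn4cccc4)c4ncccc34)C(=O)NC2=O)c2ccccc21` gives > 100000 nM as a limit, not a number
- compound 3 `CN(C)CCCn1nc(C2=C(c3cn(C)c4ccccc34)C(=O)N(c3ccccc3)C2=O)c2cccnc21` gives 31200 nM as a number

Within the data shown here, compound 3, at 31200 nM in this assay, holds the only true number in the set. The other two compounds sit at the limit of > 100000 nM in this assay, at which 2 of the 3 values shown sit, and cannot be ranked against it by size.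

Next comes compound 4 `CN(C)CCCn1nc(C2=C(c3cn(C)c4ccccc34)C(=O)NC2=O)c2cccnc21`, which has hydrogen in place of phenyl on an amide-type nitrogen in a ring.

Among the measured compounds shown here, no measured step covers this change. For the measured compounds named here, the one step available, a step that the two limits leave unreadable from compound 1 to compound 2, has no readable size and lies elsewhere in the molecule. Compound 1 and compound 2 do carry hydrogen on that ring nitrogen, as compound 4 does, but their chains end differently. From the compounds shown here alone, their position at the limit of > 100000 nM in this assay, at which 2 of the 3 values shown sit, is therefore only a caution that the weak side stays open, and it sets no size or direction.

No shift beyond the scatter is expected, and the uncertainty is wide on both sides. The expected step is a 1.6-fold lower number from compound 3 to compound 4 (0.19 log units; within the scatter), an estimate resting on very little. For compound 4 the estimated value is 20000 nM, with an expected range from 4000 nM to 90000 nM.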

Compound 4, half-maximal inhibitory concentration: > 100000 nM
Compound 4: no number, only a limit (the forecaster's own chance of this, stated with the estimate: 25%); middle value at least 5.0-fold (0.69 log units) from the limit.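

In this assay, among these compounds, hydrogen in place of phenyl on the amide-type nitrogen in a ring gives an at least 3.2-fold higher number from compound 3 to compound 4 (0.50 log units; beyond the scatter), the only readable step so far and the first sign that the group at this position can shift the read-out beyond the scatter. Among the compounds shown, the dimethylamino chain alone does not secure a number, since compound 4 carries that chain and hydrogen on the ring nitrogen and still gives only a limit, not a number: the limit of > 100000 nM in this assay, at which 3 of the 4 values shown sit. The steps from compound 1 and from compound 2 to compound 4 join two limits and cannot be read, so dimethylamino, 1H-pyrrol-1-yl and 1H-1,2,4-triazol-1-yl cannot be ranked against one another on the chain.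

From the compounds shown here alone, the true size of the loss on going from phenyl to hydrogen stays open, as only its lower bound is readable. Also open, going by these compounds, is whether a methyl, a benzyl or a substituted phenyl such as 4-methoxyphenyl on the same nitrogen would hold a number in this assay, and whether phenyl there would do so with the 1H-pyrrol-1-yl or 1H-1,2,4-triazol-1-yl chain.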